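This account rests on a few compounds, and the source may have more. Where it says the series, first, only, none or still open, it means among the compounds named here.

Compound 1 `O=S(=O)(c1ccccc1F)c1cn(C2CCNC2)c2ncccc12` gives 2 nM in an assay on HeLa cells for displacement of a labelled ligand from 5-hydroxytryptamine receptor 6 (Homo sapiens); a higher number here means a weaker inhibitor, a lower number a stronger inhibitor.
Compound 2 `CN1CCC(n2cc(S(=O)(=O)c3ccccc3F)c3cccnc32)C1` gives 5.6 nM in this assay.

Among the compounds with values here, compound 2 holds the higher of the two numbers so far, its only neighbour being compound 1, and the step of a 2.8-fold higher number from compound 1 to compound 2 (0.45 log units; beyond the scatter) separates them. Compound 3 `CN1CCC(n2cc(S(=O)(=O)c3cccc(Cl)c3)c3cccnc32)C1` has not yet been measured. It differs from compound 2 in one place: 3-chlorophenyl in place of 2-fluorophenyl on a sulfonyl sulfur. Within the data shown here, no measured step bears on this change; the one step known, from compound 1 to compound 2, concerns the amine nitrogen in the ring and leaves the group on the sulfonyl sulfur untouched, so it gives no guide to what a new aryl group on that sulfur will do. With nothing to anchor the direction, a step near or just beyond the scatter is expected, with the range kept wide. For compound 3 the estimate is 8 nM, between 2 nM and 40 nM, which would mean an expected step of a 1.4-fold higher number from compound 2 to compound 3 (0.15 log units; within the scatter).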

Compound 3, inhibition constant: 1.5 nM
The estimate for compound 3 lay 5.3-fold (0.73 log units) above the measured number, and the stated range ends above it.
By their numbers in this assay, from the lowest: compounds 3 and 1 (each within the scatter of the next); then compound 2.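

Within the data shown here, changing the group on the sulfonyl sulfur shifts the number in this assay beyond the scatter: 3-chlorophenyl in place of 2-fluorophenyl gives a 3.7-fold lower number from compound 2 to compound 3 (0.57 log units; beyond the scatter) and is the first measured step at this position. The leaving and entering groups have the same count of heavy atoms and the same carbon ring, so a step of this size arises without any change in those counts. No available evidence explains the change.

From the compounds shown here alone, the two groups differ in both the halogen and its printed position, so the step cannot be assigned to either one alone; 3-fluorophenyl, 2-chlorophenyl and plain phenyl remain open on this sulfur. Also open, going by these compounds, is whether 3-chlorophenyl has the same effect when the ring amine nitrogen carries hydrogen instead of methyl.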